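Chain-extended aryloxy quinoline analog: expected cytotoxicity

The compounds below may be only part of what the source reports. "The series", "measured", "known", "first", "only" and "open" are said of these compounds alone.

Measured compounds:
compound 1, `CCOc1ccc2c(Cl)ccnc2c1`, 3910 nM
compound 2, `Clc1ccnc2cc(OCCc3ccccc3)ccc12`, 2010 nM

Both compounds were tested in a functional assay on BGC-823 cells (Homo sapiens) for cytotoxicity, read by MTT assay, with a stated time of 48 h; a lower number here means a stronger inhibitor, a higher number a weaker inhibitor. Compound 1 gives 3910 nM and compound 2 gives 2010 nM. Compound 2 has the lowest of the two numbers, but the step of a 1.9-fold lower number from compound 1 to compound 2 (0.29 log units; within the scatter) lies within the scatter, so no ordering of the two can be claimed.

Compound 3, `Clc1ccnc2cc(OCCCc3ccccc3)ccc12`, has not yet been measured in this assay. It differs from compound 2 by benzyl in place of phenyl on a saturated chain carbon, two bonds along the chain from an oxygen on an aromatic ring. Among the compounds with values here, the only measured step that bears on this place in the molecule is a 1.9-fold lower number from compound 1 to compound 2 (0.29 log units; within the scatter), which was within the scatter. That step put the phenyl onto the chain; the present change lengthens the chain by one carbon between the oxygen and the ring. Within the data shown here, with one small, within-scatter step as the only guide, no shift beyond the scatter is expected in this assay for compound 3.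

Compound 3 is therefore estimated at 1800 nM, with a range of 700 nM to 4500 nM, corresponding to an expected step of a 1.1-fold lower number from compound 2 to compound 3 (0.05 log units; within the scatter).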

Compound 3, half-maximal inhibitory concentration: 2370 nM
For compound 3 the middle estimate is 1.3-fold (0.12 log units) below the measured one; the measured number falls inside the stated range.
By their numbers in this assay, from the lowest: compounds 2, 3 and 1 (each within the scatter of the next).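

In this assay, within the data shown here, the exchange of phenyl for benzyl on a saturated chain carbon, two bonds along the chain from an oxygen on an aromatic ring, gives a 1.2-fold higher number from compound 2 to compound 3 (0.07 log units; within the scatter) and adds a second reading at this place to the single step available before. Taken from the hydrogen of compound 1, the benzyl gives a 1.6-fold lower number from compound 1 to compound 3 (0.22 log units; within the scatter), so hydrogen, phenyl and benzyl at this place all lie within the scatter of one another, and this small set gives no sign that the number follows the group carried there. Nothing measured here offers an explanation for these numbers at this place.

The compounds shown leave open whether a longer chain, or an amine or a carboxylic acid carried on the chain in place of the benzyl, would produce a step beyond the scatter. They also leave open whether the same flat reading would hold if the chlorine on the shared core were replaced by an amine, since every compound here keeps that chlorine unchanged.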